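This account rests on a few compounds, and the source may have more. Where it says the series, first, only, none or still open, it means among the compounds named here.

Measured so far:
compound 1 `CCN(CC)c1ccc(N2C(=O)CSC2c2cccc(C(=O)NCCCCc3ccccc3)c2)cc1`: > 1000 nM
compound 2 `COc1ccccc1N1C(=O)CSC1C(=O)NCCCCc1ccccc1`: > 1000 nM

In a functional assay on HOS-TE85 cells (Homo sapiens) for inhibition, read by CCK-8 assay, with a stated time of 72 h (on this read-out lower numbers stand for stronger inhibition and higher numbers for weaker inhibition), compound 1 gives > 1000 nM, which is a limit of the assay and not a number. Compound 2 also gives a limit, > 1000 nM. Among the compounds with values here, both values sit at the limit of > 1000 nM in this assay, at which 2 of the 2 values shown sit, so compound 1 stands level with the other value shown and no measured step exists. Compound 3 `O=C(NCCCCc1ccccc1)c1cccc(C2SCC(=O)N2c2ccccc2F)c1` differs from compound 1 by 2-fluorophenyl in place of 4-(diethylamino)phenyl on an amide-type nitrogen in a ring. With nothing to build on, the step that the limit leaves unreadable from compound 1 to compound 3 is expected to stay within the scatter. Compound 3 is therefore estimated at about 2000 nM, between 700 nM and 10000 nM, probably reported again as a limit.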

Compound 3, half-maximal inhibitory concentration: 34.1 nM
Compound 3: the middle estimate sits 59-fold (1.77 log units) above what was measured; measured number below the stated range.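

In this assay, the group on the amide-type nitrogen of the ring clearly matters: 2-fluorophenyl in place of 4-(diethylamino)phenyl gives an at least 29-fold lower number from compound 1 to compound 3 (1.46 log units; beyond the scatter). This single change is enough to bring the shared core into a measurable range. Compound 1 remains at a limit, so the full size of the step cannot be read: the limit of > 1000 nM in this assay, at which 2 of the 3 values shown sit.

Going by these compounds, whether the gain comes from adding the fluorine or from losing the diethylamino group stays open. A plain phenyl or a 2-chlorophenyl at this position would help separate the two.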